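Aryl ether series: cyclohexyl to methoxyphenyl on the ether oxygen

This account rests on a few compounds, and the source may have more. Where it says the series, first, only, none or still open, it means among the compounds named here.

Three compounds of the shared core have numbers in an assay on isolated protein for inhibition of Bile acid receptor (Homo sapiens), read by TR-FRET and LanthaScreen; a lower number here means a stronger inhibitor, a higher number a weaker inhibitor. Compound 1 `CC(C)C[C@@H](c1nc2ccc(C(=O)O)cc2n1C)N1C(=O)CN(c2cccc(Oc3ccccc3)c2)C1=O` gives 18200 nM in this assay. Compound 2 `CC(C)C[C@@H](c1nc2ccc(C(=O)O)cc2n1C)N1C(=O)N(c2ccc(Oc3ccccc3)cc2)C(C)(C)C1=O` gives 105000 nM. Compound 3 `CC(C)C[C@@H](c1nc2ccc(C(=O)O)cc2n1C)N1C(=O)CN(c2ccc(OC3CCCCC3)cc2)C1=O` gives 126000 nM, the highest of the three numbers; its gap to compound 2 lies within the scatter, while compound 1 sits lower by a margin beyond the scatter. No pair among these three differs in one place only, so no single-change step is available.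

Compound 4 `COc1ccc(Oc2ccc(N3CC(=O)N([C@@H](CC(C)C)c4nc5ccc(C(=O)O)cc5n4C)C3=O)cc2)cc1` has not been measured. It differs from compound 3 by 4-methoxyphenyl in place of cyclohexyl on an oxygen on an aromatic ring. Taken one bond further out, cyclohexyloxy becomes 4-methoxyphenoxy. Among the compounds with values here, with no single-change step to lean on, the expectation for the step from compound 3 to compound 4 is a modest move toward a lower number, a 2.1-fold lower number from compound 3 to compound 4 (0.32 log units; beyond the scatter), that may or may not clear the scatter. For compound 4 the estimate in this assay is 60000 nM, with a range from 20000 nM to 180000 nM.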

Compound 4, half-maximal inhibitory concentration: 75300 nM
Beside the measured number, compound 4's estimate is 1.3-fold (0.10 log units) below it, and the stated range covers the measured number.
By their numbers in this assay, from the lowest: compound 1; then compounds 4, 2 and 3 (each within the scatter of the next).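

Within the data shown here, on an oxygen on an aromatic ring, 4-methoxyphenyl in place of cyclohexyl gives a 1.7-fold lower number from compound 3 to compound 4 (0.22 log units; within the scatter) in this assay and provides the first single-change step in this set. The step lies within the scatter, so swapping the non-aromatic ring for an aromatic ring carrying a methoxy group, with one more hydrogen-bond acceptor and two more heavy atoms, does not measurably shift the number at this position. No available evidence bears on this result.

Because ring type and the methoxy group change together in this one step, their separate contributions cannot be told apart. From the compounds shown here alone, it remains open whether an amine or a carboxylic acid on the outer ring, or a short chain such as methyl on the oxygen, would give a step beyond the scatter.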